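Removing hydroxymethyl from compound 3

The source may hold more compounds than are shown below. What is called first, only, known or untested is meant among the compounds shown, and "the series" means these compounds.

Values so far in a functional assay on A2058 cells (Homo sapiens) for antiproliferative activity, read by luminescence and CellTiter-Glo, with a stated time of 96 h (a higher number here means a weaker inhibitor, a lower number a stronger inhibitor), for the series
- compound 1 `NC(=O)c1ccc(-c2ccc(F)c(C(=O)Nc3c[nH]nc3C(=O)Nc3ccc(F)cc3)c2F)cn1` gives 295 nM
- compound 2 `O=C(Nc1ccc(F)cc1)c1n[nH]cc1NC(=O)c1c(F)ccc(-c2ccc(F)nc2)c1F` gives 6310 nM
- compound 3 `O=C(Nc1ccc(F)cc1)c1n[nH]cc1NC(=O)c1c(F)ccc(-c2cccc(CO)c2)c1F` gives "not determined" (no result reported)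

Compound 3 has no number in this assay so no step can be read from it. Compound 4 `O=C(Nc1ccc(F)cc1)c1n[nH]cc1NC(=O)c1c(F)ccc(-c2ccccc2)c1F` differs from compound 3 by hydrogen in place of hydroxymethyl on an aromatic carbon with hydrogen in place of hydroxymethyl on an aromatic carbon. Among the compounds with values here, the one measured step of a 21-fold higher number from compound 1 to compound 2 (1.33 log units; beyond the scatter) is large but comes with fluoro in place of carbamoyl on an aromatic carbon, a different change that bears only indirectly. Without a value for compound 3, no step size can be expected. Compound 4 lacks carbamoyl, as does compound 2 at 6310 nM and is therefore expected nearer that value than compound 1 at 295 nM in this assay here. Compound 4 is estimated at 3000 nM with an expected range from 800 nM to 10000 nM for now.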

Compound 4, half-maximal inhibitory concentration: 2370 nM
Beside the measured number, compound 4's estimate is 1.3-fold (0.10 log units) above it; low and high end bracket the measured number.
By their numbers in this assay, from the lowest: compound 1; then compound 4; then compound 2.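

In this assay, the unsubstituted phenyl of compound 4 gives a reference point for this outer ring: replacing 6-fluoropyridin-3-yl gives a 2.7-fold lower number from compound 2 to compound 4 (0.43 log units; beyond the scatter), and replacing 6-carbamoylpyridin-3-yl gives an 8.0-fold higher number from compound 1 to compound 4 (0.90 log units; beyond the scatter). Against phenyl, 6-carbamoylpyridin-3-yl therefore gives the lower number and 6-fluoropyridin-3-yl the higher one.

The step from compound 3 cannot be read, and no measurement offers a cause for the steps that can. As far as these compounds go, whether an aminomethyl group or a carboxylic acid in place of hydroxymethyl would bring the number towards that of compound 1 remains open.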